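A formyl in place of chloro

The source may hold more compounds than are shown below. What is called first, only, known or untested is meant among the compounds shown, and "the series" means these compounds.

Compound 2 `CN(c1ccncc1)n1cccc1Cl` shares its core with compound 1 `Clc1cccn1Nc1ccncc1` and compound 3 `CCN(c1ccncc1)n1cccc1Cl`. In a functional assay on the whole organism with Mus musculus as the target (on this read-out higher numbers stand for an effect only at larger amounts of compound and lower numbers for an effect already at smaller amounts), compound 2 gives > 20 mg/kg, which is a limit and not a number. Compound 1 gives > 20 mg/kg, also a limit. Compound 3 gives > 20 mg/kg, again a limit. All three therefore stand at the limit of > 20 mg/kg in this assay, at which 3 of the 3 values shown sit.

Compound 4 `CN(c1ccncc1)n1cccc1C=O` differs from compound 2 as follows: formyl in place of chloro on an aromatic carbon. The measured changes, a step that the two limits leave unreadable from compound 1 to compound 2 and a step that the two limits leave unreadable from compound 2 to compound 3, lie elsewhere in the molecule and have no readable size. Neither supports a direction, so no clear shift is expected. The estimated change is a step that the limit leaves unreadable from compound 2 to compound 4. For compound 4 the estimate is 30 mg/kg, with an expected range from 10 mg/kg to 80 mg/kg.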

Compound 4, dose for half-maximal effect: > 20 mg/kg
Compound 4 gave a limit, no number; the forecaster's own chance of this, stated with the estimate: 70%; the middle value lies beyond the limit too.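

For the compounds shown here, compound 2 and compound 4 both give a limit and not a number, so no step between them can be read: the limit of > 20 mg/kg in this assay, at which 4 of the 4 values shown sit. The compounds shown leave open what dose of any of them gives a half-maximal effect in this assay.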